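The source may hold more compounds than are shown below. What is called first, only, known or untested is meant among the compounds shown, and "the series" means these compounds.

Measured so far in a physicochemical assay for lipophilicity; on this read-out lower numbers stand for lower lipophilicity and higher numbers for higher lipophilicity:
compound 1 `Clc1ccc(C2=NC(c3ccccc3)CO2)c(Cl)c1`: 4.4
compound 2 `Fc1cccc(F)c1C1=NC(c2ccccc2)CO1`: 3.01
compound 3 `Fc1ccccc1C1=NC(c2ccccc2)CO1`: 3.51

Compound 3 stands second highest of the three numbers in this assay; compound 2 lies lower, compound 1 higher. Compound 4 `FC(F)(F)c1ccccc1C1=NC(c2ccccc2)CO1` differs from compound 3 by trifluoromethyl in place of fluoro on an aromatic carbon. Among the compounds with values here, the only measured step, a number 0.50 log units higher from compound 2 to compound 3 (beyond the scatter), concerns hydrogen in place of fluoro and gives no direct read on a trifluoromethyl group entering; no measured pair shows that change. Within the data shown here, the highest number so far is that of compound 1, 4.4. On this basis an upward step of a number 0.74 log units higher from compound 3 to compound 4 (beyond the scatter) is expected for compound 4, beyond the scatter. Compound 4 is therefore estimated at 4.25, in the range 3.9 to 4.6.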

Compound 4, partition coefficient: 3.71
Beside the measured number, compound 4's estimate is 0.54 log units above it; measured number outside the range, below it.
By their numbers in this assay, from the lowest: compound 2; then compounds 3 and 4 (each within the scatter of the next); then compound 1.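

In this assay, trifluoromethyl in place of fluoro on an aromatic carbon, ortho to a large group, gives a number 0.20 log units higher from compound 3 to compound 4 (within the scatter). Within the data shown here, this position therefore takes either group with no difference that this read-out can resolve, whereas the one earlier step, a number 0.50 log units higher from compound 2 to compound 3 (beyond the scatter), lies beyond the scatter. No evidence on the cause of this result is at hand. Going by these compounds, whether an amine or a carboxylic acid at this place would separate from compound 3 remains open. Also open, on these data alone, is whether compound 4's result would hold with a second group on the same ring.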